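Aromatic Amine Swap: From Cyclopentyl Amine to Sulfoamino Pyrrolidine

The source may hold more compounds than are shown below. What is called first, only, known or untested is meant among the compounds shown, and "the series" means these compounds.

Compound 1 `O=C(CCc1ccc(C(F)(F)F)cc1)Nc1ccc2nc(N3CC4CCC3C4)ccc2c1`: 150 nM
Compound 2 `CN(c1ccc2cc(NC(=O)CCc3ccc(C(F)(F)F)cc3)ccc2n1)C1CCCC1`: 350 nM
Compound 3 `O=C(CCCCCCCCCCCCc1ccc(C(F)(F)F)cc1)Nc1ccc2nc([N+]34CCC(CC3)CC4)ccc2c1`: 25 nM

In a functional assay on HEK293 cells for activation of melanin-concentrating hormone receptor 1 (Rattus norvegicus), read by inositol phosphate accumulation (a lower number here means that less compound is needed, a higher number that more compound is needed for the effect), compound 2 gives the highest of the three numbers; compound 1 sits closest, compound 3 furthest. Compound 4 `O=C(CCc1ccc(C(F)(F)F)cc1)Nc1ccc2nc(N3CCC(NS(=O)(=O)O)C3)ccc2c1` differs from compound 2 as follows: 3-(sulfoamino)pyrrolidin-1-yl in place of cyclopentyl(methyl)amino on an aromatic carbon. For the measured compounds named here, no measured step covers this change. Going by the values given here, the only step at the same place, a 2.3-fold higher number from compound 1 to compound 2 (0.37 log units; beyond the scatter), shows that a replacement there shifts the number modestly. Since compound 3 carries a very different chain, its value says little here. A modest step in this assay is expected for compound 4, most likely toward a higher number, a 1.7-fold higher number from compound 2 to compound 4 (0.23 log units; within the scatter). Compound 4 is estimated at 600 nM, within 150 nM to 2500 nM.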

Compound 4, half-maximal effective concentration: 50 nM
The estimate for compound 4 lay 12-fold (1.08 log units) above the measured number; the measured number lies below the stated range.
By their numbers in this assay, from the lowest: compounds 3 and 4 (each within the scatter of the next); then compound 1; then compound 2.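

In this assay, replacing the cyclopentyl(methyl)amino group with 3-(sulfoamino)pyrrolidin-1-yl gives a 7.0-fold lower number from compound 2 to compound 4 (0.85 log units; beyond the scatter), whereas the earlier step at this place ran toward a higher number. The same group also beats the bridged amine of compound 1, with a 3.0-fold lower number from compound 1 to compound 4 (0.48 log units; beyond the scatter), so compound 4 has the lowest number among the three compounds sharing the short chain. Nothing available accounts for this shift. Compound 4 brings the pyrrolidine ring and the sulfoamino group together, and the compounds shown do not separate their contributions. From the compounds shown here alone, a plain pyrrolidin-1-yl, or a carboxylic acid or an amine in place of the sulfoamino group on that ring, remains open.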